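A few compounds are considered here, and "the series" means these few. Any claim that something is new, unique, unknown or untested is made for them only; others in the source may bear on it.

In a functional assay on K562 cells (Homo sapiens) for cytotoxicity, read by trypan blue exclusion, with a stated time of 96 h (a lower number here means a stronger inhibitor, a higher number a weaker inhibitor), compound 1 (`COc1cc(OC)c(/C=C/S(=O)(=O)Cc2ccc(OC)cc2[N+](=O)[O-])c(OC)c1`) gives 20000 nM and compound 2 (`COc1cc(OC)c(/C=C/[S+]([O-])Cc2ccc(OC)c([N+](=O)[O-])c2)c(OC)c1`) gives 15000 nM. Compound 3 (`COC(=O)CNc1cc(CS(=O)(=O)/C=C/c2c(OC)cc(OC)cc2OC)ccc1OC`) gives 100 nM, the lowest number of the three and beyond the scatter from both others. Compound 4 (`COC(=O)C(C)(C)Nc1cc(CS(=O)(=O)/C=C/c2c(OC)cc(OC)cc2OC)ccc1OC`) has not yet been measured. It differs from compound 3 at one place: 1-(methoxycarbonyl)-1-methylethyl in place of (methoxycarbonyl)methyl on a nitrogen on an aromatic ring. Among the compounds with values here, no measured pair isolates a change at this nitrogen, so the expectation rests only on compound 3 at 100 nM and on the structural change. A moderate step towards a weaker inhibitor is expected in this assay, and it may not clear the scatter. The estimated move is a 2.0-fold higher number from compound 3 to compound 4 (0.30 log units; within the scatter). For compound 4 the expected value is 200 nM, with an estimated range of 60 nM to 1000 nM.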

Compound 4, half-maximal inhibitory concentration: 800 nM
For compound 4 the middle estimate is 4.0-fold (0.60 log units) below the measured one; low and high end bracket the measured number.
By their numbers in this assay, from the lowest: compound 3; then compound 4; then compounds 2 and 1 (each within the scatter of the next).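

In this assay, 1-(methoxycarbonyl)-1-methylethyl in place of (methoxycarbonyl)methyl on a nitrogen on an aromatic ring gives an 8.0-fold higher number from compound 3 to compound 4 (0.90 log units; beyond the scatter) and this step lies beyond the scatter, so this position responds to the change. With this substitution, compound 4 still reads 800 nM in this series. Nothing available here accounts for the size of the step.

Going by these compounds, whether a single methyl on that carbon gives part of the step remains open. So does the effect of a carboxylic acid in place of the methyl ester, or of a longer chain on the same nitrogen.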